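The source may report more compounds than this note shows. Statements on the series, on what has been measured and on what is new or still open speak of the compounds shown alone.

In a functional assay on BGC-823 cells (Homo sapiens) for antiproliferative activity, read by sulforhodamine B assay, tested at 100 ug/mL (on this read-out lower numbers stand for less inhibition and higher numbers for more inhibition at the one concentration tested (going by the name of the read-out)), the measured compounds so far are:
compound 1 `O=C1CCCCC1S(=O)(=O)Nc1cc(C(F)(F)F)ccc1C(F)(F)F`: 57.7%
compound 2 `O=C1CCCCC1S(=O)(=O)Nc1cc(C(F)(F)F)cc(C(F)(F)F)c1`: 70.8%

Compound 2 stands highest of the two numbers shown; its nearest neighbour, compound 1, lies lower by a gap beyond the usual scatter. Among the compounds with values here, no step between measured compounds is available, so the size of a single change cannot be read from the set. Compound 3 `O=C1CCCCC1S(=O)(=O)Nc1cccc(C(F)(F)F)c1` differs from compound 2 by hydrogen in place of trifluoromethyl on an aromatic carbon. With the trifluoromethyl gone, a moderate drop in inhibition is expected, a number 15.8 percentage points lower from compound 2 to compound 3 (beyond the scatter). For compound 3 the estimated value in this assay is 55%, with a range of 35% to 75%.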

Compound 3, a percentage reported as inhibition, at one concentration (the size of the read-out at that concentration, not a potency): 21.7%
The estimate for compound 3 lay 33.3 percentage points above the measured number; the measured number lies below the stated range.
By their numbers in this assay, from the lowest: compound 3; then compound 1; then compound 2.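

In this assay, a second trifluoromethyl on the aromatic ring proves to matter at either of the two places shown: replacing it with hydrogen gives a large loss a number 49.1 percentage points lower from compound 2 to compound 3 (beyond the scatter) and another a number 36 percentage points lower from compound 1 to compound 3 (beyond the scatter). Compound 3 keeps one trifluoromethyl, so one such group alone does not hold the inhibition seen with two. No measurement at hand accounts for the size of these steps.

On these data alone, whether a smaller group such as methyl, chlorine or a nitrile could stand in for the lost trifluoromethyl remains open. So does the effect of removing the remaining trifluoromethyl from compound 3.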